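Chloro to methyl on the second core of the series

The compounds below may be only part of what the source reports. "The series", "measured", "known", "first", "only" and "open" are said of these compounds alone.

Of the compounds shown here, three have been measured in a functional assay on C6 cells (Rattus norvegicus) for cytotoxicity, read by MTT assay, with a stated time of 24 h, tested at 12 ug/mL; on this read-out lower numbers stand for a stronger effect and higher numbers for a weaker effect at the one concentration tested. Compound 1 `Cc1ccc(-c2cs/c(=N/NC(=O)CSc3nnnn3-c3ccccc3)n2-c2ccccc2)cc1` gives 55.1%. Compound 2 `O=C(CSc1nnnn1-c1ccccc1)N/N=c1/scc(-c2ccc(Cl)cc2)n1-c1ccccc1` gives 69.3%. Compound 3 `O=C(CSc1ncccn1)N/N=c1/scc(-c2ccc(Cl)cc2)n1-c1ccccc1` gives 91.6%, the highest of the three. Compound 2 and compound 3 differ in their cores by pyrimidin-2-yl in place of 1-phenyl-1H-tetrazol-5-yl on a sulfur, and the step of a number 22.3 percentage points higher from compound 2 to compound 3 (beyond the scatter). Compound 4 `Cc1ccc(-c2cs/c(=N/NC(=O)CSc3ncccn3)n2-c2ccccc2)cc1` has not been measured; it differs from compound 3 by methyl in place of chloro on an aromatic carbon. The same change, (methyl in place of chloro on an aromatic carbon), is already measured once: a number 14.2 percentage points lower from compound 2 to compound 1 (beyond the scatter). The place lines of the two changes read the same, so the change is taken as the same kind, now made on the core of compound 3. Among the compounds with values here, for compound 4 a step of similar direction is expected, a number 14.6 percentage points lower from compound 3 to compound 4 (beyond the scatter), resting on the one earlier step from compound 2 to compound 1 only. Compound 4 is estimated at 77%, between 60% and 92%.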

Compound 4, a percentage reported as activity, at one concentration (the size of the read-out at that concentration, not a potency): 83%
The estimate for compound 4 lay 6 percentage points below the measured number, and the stated range covers the measured number.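

In this assay, methyl in place of chloro on the pyrimidin-2-yl core gives a number 8.6 percentage points lower from compound 3 to compound 4 (within the scatter), so on this core the change cannot be told from scatter, and its step does not differ from the earlier one: the same change on two cores in this assay, a number 14.2 percentage points lower (beyond the scatter) from compound 2 to compound 1 and a number 8.6 percentage points lower (within the scatter) from compound 3 to compound 4, 5.6 percentage points apart, within the scatter of two such steps

Pyrimidin-2-yl in place of 1-phenyl-1H-tetrazol-5-yl on the sulfur gives a number 27.9 percentage points higher from compound 1 to compound 4 (beyond the scatter), and this change also carries over between the two cores: the same change on two cores in this assay, a number 22.3 percentage points higher (beyond the scatter) from compound 2 to compound 3 and a number 27.9 percentage points higher (beyond the scatter) from compound 1 to compound 4, 5.6 percentage points apart, within the scatter of two such steps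

Two pairs show agreement within the scatter only; they do not show that the chloro to methyl change has a real effect on every core, and a single concentration gives no potency.

The compounds shown leave open how a methoxy group or an amine would read on that aromatic carbon. Also open, as far as these compounds go, is whether either change holds with another group on the sulfur, such as a carboxylic acid chain.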